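The source may report more compounds than this note shows. Statements on the series, on what has been measured and on what is new or still open speak of the compounds shown alone.

Measured in an assay on isolated protein for inhibition of serine/threonine-protein kinase D2 (Homo sapiens), read by mobility shift assay, tested at 30 uM; a higher number here means more inhibition at the concentration tested (going by the name of the read-out), a lower number less inhibition:
- compound 1 `Cc1cc2[nH]nc(N)c2c(N2CCCCC2)n1`: 14%
- compound 2 `Cc1cc2c(c(N)nn2C)c(N2CCCCC2)n1`: 16%
- compound 3 `Cc1cc2nn(-c3ccccc3)c(N)c2c(=O)[nH]1`: -1%

Compound 2 and compound 1 lie within the scatter of each other; compound 3 sits below both by more than the scatter, so compound 2 gives one of the two higher numbers of the three, with no ranking possible against compound 1. Within the data shown here, the single measured step, a number 2 percentage points higher from compound 1 to compound 2 (within the scatter), concerns a methyl on an aromatic nitrogen and does not bear on the change now in question.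

Compound 4 `Cc1cc2c(cn1)c(N)nn2C` differs from compound 2 as follows: hydrogen in place of piperidin-1-yl on an aromatic carbon

Among the measured compounds shown here, no measured pair shows this change. For the measured compounds named here, the only indication is that compound 3, which also lacks a piperidin-1-yl but on a different core, gives -1%. A downward step is therefore expected, though with little support.

For compound 4 the expected step is a number 11 percentage points lower from compound 2 to compound 4 (beyond the scatter), giving an estimated 5% (range -8% to 18%) in this assay.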

Compound 4, a percentage reported as inhibition, at one concentration (the size of the read-out at that concentration, not a potency): -3%
Estimate against measurement, compound 4: 8 percentage points above; low and high end bracket the measured number.
By their numbers in this assay, from the lowest: compounds 4 and 3 (each within the scatter of the next); then compounds 1 and 2 (each within the scatter of the next).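

Among these compounds, replacing piperidin-1-yl with hydrogen on the aromatic carbon next to the ring nitrogen gives a number 19 percentage points lower from compound 2 to compound 4 (beyond the scatter) in this assay, the first direct reading of this change. On this core, the small inhibition of compound 2 at the tested concentration depends on piperidin-1-yl being at this position. No available measurement gives a reason for the step. As far as these compounds go, it remains open whether a morpholine ring, a dimethylamino group or a longer amine chain at this position would keep or raise the number, and whether the step also holds for compound 1, with hydrogen on the aromatic nitrogen.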